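The source may report more compounds than this note shows. Statements on the series, on what has been measured and on what is new or still open speak of the compounds shown alone.

Measured so far: compound 1 `COc1cc(-c2nn(-c3cccc(NC(=O)Nc4cc(C(F)(F)F)cc(C(F)(F)F)c4)c3)cc2-c2ccncc2)ccc1Cl` gives 826 nM in a functional assay on IGROV-1 cells (Homo sapiens) for inhibition, read by sulforhodamine B assay, with a stated time of 48 h; a higher number here means a weaker inhibitor of growth, a lower number a stronger inhibitor of growth; compound 2 `COc1cc(-c2nn(-c3cccc(NC(=O)Nc4ccc(Cl)c(Cl)c4)c3)cc2-c2ccncc2)ccc1Cl` gives 1180 nM; compound 3 `O=C(Nc1cccc(-n2cc(-c3ccncc3)c(-c3ccc(Cl)c(O)c3)n2)c1)Nc1ccc(Cl)c(Cl)c1` gives 1770 nM.

Among these three numbers compound 2 stands second highest, and its gaps to both neighbours are within the scatter: compound 1 sits at a slightly lower number and compound 3 at a slightly higher one, so none of the three can be called stronger or weaker than another on this evidence.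

Compound 4 `COc1cc(-c2nn(-c3cccc(NC(=O)Nc4ccc(Cl)c(C(F)(F)F)c4)c3)cc2-c2ccncc2)ccc1Cl` has not yet been measured. It differs from compound 2 in one place: trifluoromethyl in place of chloro on an aromatic carbon. Among the compounds with values here, the only step measured between neighbouring compounds is a different change, a 1.5-fold higher number from compound 2 to compound 3 (0.18 log units; within the scatter), and it stayed within the scatter. Within the data shown here, no measured pair isolates the swap of chloro for trifluoromethyl on that ring. The nearest hint is that compound 1, which carries two trifluoromethyl groups on the same ring, and compound 2, which carries two chloro groups there, give numbers that lie within the scatter of each other.

On that basis the step is expected to be small: the number for compound 4 is estimated at 950 nM, with a range from 450 nM to 2000 nM, meaning an expected change of a 1.2-fold lower number from compound 2 to compound 4 (0.09 log units; within the scatter).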

Compound 4, concentration for 50% growth inhibition: 1200 nM
For compound 4 the middle estimate is 1.3-fold (0.10 log units) below the measured one; the range from low to high includes it.
By their numbers in this assay, from the lowest: compounds 1, 2, 4 and 3 (each within the scatter of the next, the first and the last beyond it).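

In this assay, putting trifluoromethyl on the aromatic carbon that carries a chloro group in compound 2 gives a 1.0-fold higher number from compound 2 to compound 4 (0.01 log units; within the scatter), so this swap leaves the read-out within the scatter even though 4 heavy atoms enter where 1 leaves. Within the data shown here, no earlier pair isolated this carbon, and this one shows that, at a place ortho to a chloro group and meta to a large group, these two groups cannot be told apart by growth inhibition in these cells. Nothing in the available information explains why the two groups read alike.

As far as these compounds go, what a group of a different kind would do on this carbon remains open, for example a nitrile, an amine, a carboxylic acid or a longer chain such as propyl. From the compounds shown here alone, it is also open whether the same swap would stay within the scatter at the remaining chloro group on this ring, or whether the result holds when the methoxy group on the core of compound 4 is replaced by another group.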